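This account rests on a few compounds, and the source may have more. Where it says the series, first, only, none or still open, it means among the compounds named here.

Three compounds have been measured in an in vitro functional assay on SH-EP1 cells for agonist activity at Neuronal acetylcholine receptor; alpha4/beta2 (Homo sapiens), read by FLIPR and calcium flux; a lower number here means that less compound is needed, a higher number that more compound is needed for the effect:

Compound 1, `COc1cncc(C2=CC3CC(C2)CN(C)C3)c1`, gives 5130 nM.
Compound 2, `CN1C[C@H]2C=C(c3cccnc3)C[C@H](C2)C1`, gives 7660 nM.
Compound 3, `Clc1ccc(C2=CC3CNCC(C2)C3)cn1`, gives 35 nM.

Compound 2 has the highest number of the three. Compound 1 lies close to it, within the usual scatter, so the two cannot be told apart. Within the data shown here, compound 3 stands far away, with a number that is much lower, beyond the scatter; it is the only compound here that carries no methyl on the ring amine nitrogen.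

Compound 4, `C1=C(c2cccnc2)C[C@H]2CNC[C@@H]1C2`, has not been measured yet. It differs from compound 2 in one place: hydrogen in place of methyl on an amine nitrogen in a ring. Among the measured compounds shown here, no measured pair shows this exact change on its own, so the size of the step is open. The values of compound 3 and compound 2 do show, without a direct comparison, that the one unmethylated amine among the measured compounds sits at a far lower number than the two methylated ones. On that basis the step from compound 2 to compound 4 is expected to go toward a lower number, and to be larger than the scatter: a 51-fold lower number from compound 2 to compound 4 (1.71 log units; beyond the scatter). Compound 4 is therefore estimated at 150 nM, within a range from 25 nM to 900 nM.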

Compound 4, half-maximal effective concentration: 12 nM
For compound 4 the middle estimate is 13-fold (1.10 log units) above the measured one, and the stated range ends above it.
By their numbers in this assay, from the lowest: compound 4; then compound 3; then compounds 1 and 2 (each within the scatter of the next).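

In this assay, among these compounds, this pair gives the first direct reading of the change: hydrogen in place of methyl on an amine nitrogen in a ring brings a 640-fold lower number from compound 2 to compound 4 (2.81 log units; beyond the scatter) and is a large step. The earlier contrast between methylated and unmethylated amines came from compounds that also differed elsewhere, whereas here everything else stays the same and this one position alone carries the whole step. Nothing at hand explains why the step is so large.

Only hydrogen and methyl appear on this nitrogen, which leaves an ethyl group or a longer chain there open. Whether the step holds the same size on the cores of compound 1 and compound 3 is also open: neither has a partner differing only by this change among the compounds shown.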